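Ethyl ester on the defluorinated acid

The source may report more compounds than this note shows. Statements on the series, on what has been measured and on what is new or still open speak of the compounds shown alone.

Compound 1 `O=C(O)c1cc(N2C(=O)C3=C(CCCC3)C2=O)c(F)cc1Cl`: 1000 nM
Compound 2 `O=C(O)c1cc(N2C(=O)C3=C(CCCC3)C2=O)ccc1Cl`: > 100000 nM, a limit of the assay rather than a number
Compound 3 `COC(=O)c1cc(N2C(=O)C3=C(CCCC3)C2=O)c(F)cc1Cl`: 67.6 nM

All three were tested in a functional assay on the whole organism for inhibition, with Scenedesmus acutus as the target; a higher number here means a weaker inhibitor, a lower number a stronger inhibitor. Compound 2 sits at the limit of > 100000 nM in this assay, at which 1 of the 3 values shown sits, so its true position is known only as a limit. Two measured steps exist. One is an at least 100-fold higher number from compound 1 to compound 2 (2.00 log units; beyond the scatter), where hydrogen replaces fluoro on an aromatic carbon. The other is a 15-fold lower number from compound 1 to compound 3 (1.17 log units; beyond the scatter), where methyl replaces hydrogen on an oxygen next to a carbonyl group; it shows that turning the acid into a small ester gives a markedly stronger inhibitor.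

Compound 4 `CCOC(=O)c1cc(N2C(=O)C3=C(CCCC3)C2=O)ccc1Cl` differs from compound 2 by ethyl in place of hydrogen on an oxygen next to a carbonyl group. This closely mirrors the change from compound 1 to compound 3, only with ethyl in place of methyl, so that step is the one that bears on it. A step of comparable size toward a lower number is expected, an at least 5.0-fold lower number from compound 2 to compound 4 (0.69 log units; beyond the scatter), though the starting point is itself only a limit. Compound 4 is therefore estimated at 20000 nM, with a range from 3000 nM to 200000 nM.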

Compound 4, half-maximal inhibitory concentration: 1910 nM
Compound 4: the middle estimate sits 10-fold (1.02 log units) above what was measured; measured number below the stated range.
By their numbers in this assay, from the lowest: compound 3; then compounds 1 and 4 (each within the scatter of the next). At a limit, above all of these: compound 2.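

Replacing the hydrogen of the carboxy group with ethyl, which turns carboxy into ethoxycarbonyl, gives an at least 52-fold lower number from compound 2 to compound 4 (1.71 log units; beyond the scatter) in this assay. Until now, the gain from turning the acid into an ester had been seen only with the fluoro group present and only with methyl, whereas this pair shows it without the fluoro group and with ethyl, so both acid and ester pairs shown now point the same way. The change also yields a real reading, with compound 4 at 1910 nM. The true size of the step stays unknown, as compound 2 gives only a limit of the assay and not a number: the limit of > 100000 nM in this assay, at which 1 of the 4 values shown sits.

Methyl and ethyl sit on cores that differ in the fluoro group, so the compounds shown cannot separate the effect of the ester chain from that of the fluoro group among the esters. On these data alone, how a longer chain such as butyl, or an amide in place of the ester, would behave at this position also remains open.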